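Oxan-2-yl ether: a single stereocentre drawn the other way

The source may report more compounds than this note shows. Statements on the series, on what has been measured and on what is new or still open speak of the compounds shown alone.

In a functional assay on HeLa cells (Homo sapiens) for antiproliferative activity (a lower number here means a stronger inhibitor, a higher number a weaker inhibitor), compound 1 `COCO[C@@H]1/C=C(\C)CC[C@]2([C@@](C)(O)C(=O)SCc3oc(=O)oc3C)CC(=O)N([C@H](C)c3nc(cs3)/C=C/C=C/C1=O)[S+]2[O-]`, the methoxymethyl ether, gives 0.17 nM. Among the compounds with values here, compound 2 `C/C1=C\[C@@H](O[C@@H]2CCCCO2)C(=O)/C=C/C=C/c2csc(n2)[C@@H](C)N2C(=O)C[C@@]([C@@](C)(O)C(=O)SCc3oc(=O)oc3C)(CC1)[S+]2[O-]`, with oxan-2-yl in that place, gives 0.67 nM, the higher of the two numbers so far. Compound 3 `C/C1=C\[C@@H](O[C@H]2CCCCO2)C(=O)/C=C/C=C/c2csc(n2)[C@@H](C)N2C(=O)C[C@@]([C@@](C)(O)C(=O)SCc3oc(=O)oc3C)(CC1)[S+]2[O-]` is unmeasured. Its difference from compound 2 is the two compounds have the same atoms and bonds; at least one stereo element is drawn with a configuration in one of them and without one in the other: 1 of 9 stereo elements differ; a stereocentre at a saturated ring carbon is drawn R in compound 2 and S in compound 3: a stereocentre at a saturated ring carbon is drawn R in compound 2 and S in compound 3.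

Within the data shown here, only one measured step bears on this, and only indirectly: a 3.9-fold higher number from compound 1 to compound 2 (0.60 log units; beyond the scatter). Among the measured compounds shown here, that step exchanges the whole group, and no measured pair isolates this stereocentre. The data give no direction, so no step beyond the scatter is expected in this assay. The estimated step is a 1.0-fold higher number from compound 2 to compound 3 (0.02 log units; within the scatter). For compound 3 the expected value is 0.7 nM, with an estimated range of 0.25 nM to 1.8 nM.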

Compound 3, half-maximal inhibitory concentration: 2.4 nM
Compound 3: the middle estimate sits 3.4-fold (0.54 log units) below what was measured, and the stated range ends below it.
By their numbers in this assay, from the lowest: compound 1; then compound 2; then compound 3.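

In this assay, the stereocentre at the saturated ring carbon of the oxan-2-yl group matters on its own, with no atom or bond changed: a 3.6-fold higher number from compound 2 to compound 3 (0.55 log units; beyond the scatter). The exchange of methoxymethyl for oxan-2-yl therefore has no single size, reading a 14-fold higher number from compound 1 to compound 3 (1.15 log units; beyond the scatter) for one drawn form against a 3.9-fold higher number from compound 1 to compound 2 (0.60 log units; beyond the scatter) for the other. The reading of this stereocentre carries one caution: the fact that one of compounds 2 and 3 is drawn with a defined configuration and the other without, at the place where they differ

Still open, from the compounds shown here alone, is how the free hydroxyl or an oxolan-2-yl ether on this oxygen would compare with these ethers. Also open, going by these compounds, is whether a stereocentre in such a smaller ring would move the number in this assay in the same direction.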